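The compounds below may be only part of what the source reports. "The series", "measured", "known", "first", "only" and "open" are said of these compounds alone.

Of the compounds shown here, three sharing one core have been tested in a functional assay on Huh7.5.1 cells (Homo sapiens) for cytotoxicity, read by MTT assay, with a stated time of 72 h; on this read-out higher numbers stand for lower toxicity in this test and lower numbers for higher toxicity in this test: compound 1 (`C=c1[nH]c(=O)/c(=C/c2cc(C(C)(C)C)cc(C(C)(C)C)c2)[nH]c1=O`), compound 2 (`C=c1[nH]c(=O)/c(=C/c2ccc(C)cc2)[nH]c1=O`) and compound 3 (`C=c1[nH]c(=O)/c(=C/c2cc(OC)c(OC)c(OC)c2)[nH]c1=O`). Compound 1 gives > 20000 nM as a limit of the assay, not a number. Compound 2 gives > 20000 nM, again only a limit and not a number. Compound 3 gives > 20000 nM as a limit too. Compound 2 therefore stands with the other two, and the whole record so far is the limit of > 20000 nM in this assay, at which 3 of the 3 values shown sit, with no number against which a step could be measured.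

The next compound is compound 4 (`C=c1[nH]c(=O)/c(=C/c2ccc(-c3ccccc3)cc2)[nH]c1=O`). It differs from compound 2 by phenyl in place of methyl on an aromatic carbon, para to a large group (phenyl in place of methyl on an aromatic carbon). Going by the values given here, no step between measured compounds is available as a guide. In this assay the expected change is none beyond the scatter, and the estimated step is a number no higher from compound 2 to compound 4 (the limit leaves the size open) in size. This expectation rests on compound 1, a heavier compound that still reads as the limit of > 20000 nM in this test. Compound 4 may well be reported only as a limit again. For compound 4 the estimated value is 20000 nM, with an expected range from 10000 nM to 40000 nM if a number is obtained.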

Compound 4, half-maximal cytotoxic concentration: > 20000 nM
Compound 4: no number, only a limit (the forecaster's own chance of this, stated with the estimate: 75%); the middle value lies on the limit itself.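

Compound 2 and compound 4 are both limits and not numbers in this assay, so no step can be read between them, and the record stays at a single reading: the limit of > 20000 nM in this assay, at which 4 of the 4 values shown sit.

The compounds shown leave open what half-maximal cytotoxic concentration any of them has as a number, and which change on the shared core, if any, would yield one.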